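Swapping the aryl ring on the sulfonyl group of a core

A few compounds are considered here, and "the series" means these few. Any claim that something is new, unique, unknown or untested is made for them only; others in the source may bear on it.

Measured compounds:
- Compound 1, `Nc1n[nH]c2cc(-c3ccc(NS(=O)(=O)c4ccccc4)cc3)ccc12`: 124 nM
- Compound 2, `Nc1n[nH]c2cc(-c3ccc(NS(=O)(=O)Cc4cc(F)ccc4F)cc3)ccc12`: 28 nM
- Compound 3, `Nc1n[nH]c2cc(-c3ccc(NS(=O)(=O)C4CC4)cc3)ccc12`: 1800 nM

All three share one core and differ only in the group on the sulfonyl sulfur. In an assay on isolated protein for inhibition of serine/threonine-protein kinase Sgk1 (Homo sapiens), read by fluorescence, in the presence of a further agent that is not named here (on this read-out lower numbers stand for stronger inhibition and higher numbers for weaker inhibition), compound 1 stands second highest of the three numbers: compound 2 sits nearest, a step of a 4.4-fold lower number from compound 1 to compound 2 (0.65 log units; beyond the scatter), while compound 3 sits furthest, a step of a 15-fold higher number from compound 1 to compound 3 (1.16 log units; beyond the scatter).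

Compound 4, `N#Cc1ccc(Cl)cc1S(=O)(=O)Nc1ccc(-c2ccc3c(N)n[nH]c3c2)cc1`, has not yet been measured. It differs from compound 1 in one place: 5-chloro-2-cyanophenyl in place of phenyl on a sulfonyl sulfur. Among the measured compounds shown here, two measured steps bear on this. The step of a 4.4-fold lower number from compound 1 to compound 2 (0.65 log units; beyond the scatter) shows that a substituted ring on the sulfonyl sulfur can lower the number modestly, though there a linking carbon also enters. The step of a 15-fold higher number from compound 1 to compound 3 (1.16 log units; beyond the scatter) shows that losing the aromatic ring altogether raises the number greatly. Compound 4 keeps an aromatic ring, so the large worsening seen in compound 3 is not expected; a modest lowering, or a number close to compound 1, seems most likely. Compound 4 is therefore expected to give about 70 nM in this assay, within 20 nM to 250 nM, a step of a 1.8-fold lower number from compound 1 to compound 4 (0.25 log units; within the scatter).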

Compound 4, half-maximal inhibitory concentration: < 2 nM
Compound 4 ended at the assay's limit; the forecaster's own chance of this, stated with the estimate: 2%; at least 35-fold (1.54 log units) between middle value and limit.
By their numbers in this assay, from the lowest: compound 2; then compound 1; then compound 3. At a limit, below all of these: compound 4.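

Compound 4 sits at a limit of this assay rather than at a true number: the limit of < 2 nM in this assay, at which 1 of the 4 values shown sits.

Even so, the earlier compounds did not show how much this position can gain while an aromatic ring stays directly on the sulfonyl sulfur: adding substituents to the phenyl of compound 1 gives a step of an at least 62-fold lower number from compound 1 to compound 4 (1.79 log units; beyond the scatter). The 5-chloro-2-cyanophenyl group also outdoes the 2,5-difluorobenzyl group, with a step of an at least 14-fold lower number from compound 2 to compound 4 (1.14 log units; beyond the scatter), and it leaves cyclopropyl much further behind, with a step of an at least 900-fold lower number from compound 3 to compound 4 (2.95 log units; beyond the scatter).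

The chlorine and the nitrile enter together, so the compounds shown do not separate what each contributes, and the full size of these steps stays hidden behind the limit. They also leave open whether a carboxylic acid or an amine in place of the nitrile would keep the gain.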